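A hydroxy swap at the edge of an assay limit

The source may hold more compounds than are shown below. What is called first, only, known or untested is meant among the compounds shown, and "the series" means these compounds.

Compound 1 `Cc1nc(-c2cccnc2)sc1-c1nnc(-c2ccc([N+](=O)[O-])cc2)o1`: > 100 ug/mL, a limit
Compound 2 `Cc1nc(-c2cccnc2)sc1-c1nnc(-c2ccccc2)o1`: > 100 ug/mL, a limit
Compound 3 `Cc1nc(-c2cccnc2)sc1-c1nnc(-c2ccc(Cl)cc2)o1`: > 100 ug/mL, a limit

In an ADME assay on HCT-116 cells (Homo sapiens) for cytotoxicity, read by MTT assay (on this read-out higher numbers stand for lower toxicity in this test and lower numbers for higher toxicity in this test), compound 3 gives > 100 ug/mL, which is a limit of the assay and not a number. Compound 4 `Cc1nc(-c2cccnc2)sc1-c1nnc(-c2ccc(O)cc2)o1` has not yet been measured. It differs from compound 3 by hydroxy in place of chloro on an aromatic carbon; in words, hydroxy in place of chloro on an aromatic carbon, para to a large group.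

Going by the values given here, three measured steps bear on this change: a step that the two limits leave unreadable from compound 1 to compound 2, a step that the two limits leave unreadable from compound 1 to compound 3 and a step that the two limits leave unreadable from compound 2 to compound 3. None of them has a readable size, and none brings in a hydroxy group, so they give no measure of how far this change might move the read-out. With compound 3 and its two neighbours held at the limit of > 100 ug/mL in this assay, at which 3 of the 3 values shown sit, no step beyond the usual scatter is expected in this assay, and no direction can be given. The expected step is a step that the limit leaves unreadable from compound 3 to compound 4. For compound 4 the estimated value is 120 ug/mL, with an expected range from 50 ug/mL to 250 ug/mL.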

Compound 4, half-maximal cytotoxic concentration: > 100 ug/mL
Compound 4: only a limit was reported (the forecaster's own chance of this, stated with the estimate: 70%); the middle value is on the limit's open side.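

In this assay no step from compound 1, compound 2 or compound 3 to compound 4 can be read, as all four stand at one limit: the limit of > 100 ug/mL in this assay, at which 4 of the 4 values shown sit.

The compounds shown leave open whether the four differ at all in this toxicity read-out, and at what concentration any of them would become toxic to these cells.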